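Amide Aryl Variation on a Shared Core: Estimating Compound 4

The source may hold more compounds than are shown below. What is called first, only, known or untested is meant among the compounds shown, and "the series" means these compounds.

Measured compounds:
compound 1 `Cc1ccc(C(=O)Nc2cccc(-c3oc4cc(-c5ccc(F)cc5)ccc4c(=O)c3O)c2)cc1` — in a functional assay on HCC1937 cells (Homo sapiens) for antiproliferative activity, read by CCK-8 assay, with a stated time of 72 h (on this read-out higher numbers stand for weaker inhibition and lower numbers for stronger inhibition), compound 1 gives 7110 nM
compound 2 `O=C(Nc1cccc(-c2oc3cc(-c4ccc(F)cc4)ccc3c(=O)c2O)c1)c1ccc(Br)cc1` — compound 2 gives 8630 nM
compound 3 `O=C(Nc1cccc(-c2oc3cc(-c4ccc(F)cc4)ccc3c(=O)c2O)c1)c1cccc(F)c1` — compound 3 gives 6590 nM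

The three measured compounds share the core of compound 1 and differ only in the aryl group attached to the carbonyl carbon of the amide. Compound 1 stands second highest of the three numbers. Its nearest neighbour is compound 3, with a 1.1-fold lower number from compound 1 to compound 3 (0.03 log units; within the scatter), and its furthest is compound 2, with a 1.2-fold higher number from compound 1 to compound 2 (0.08 log units; within the scatter). Between the other two the step is a 1.3-fold lower number from compound 2 to compound 3 (0.12 log units; within the scatter). All three steps fall within the scatter, so the three numbers cannot be told apart.

Compound 4 `COc1ccc(C(=O)Nc2cccc(-c3oc4cc(-c5ccc(F)cc5)ccc4c(=O)c3O)c2)c(F)c1` has not yet been measured. Relative to compound 1 the change is 2-fluoro-4-methoxyphenyl in place of 4-methylphenyl on a carbonyl carbon. The entering group carries one hydrogen-bond acceptor where the leaving group carries none. The three measured steps bear directly on this change: each of them also exchanges the aryl group on the carbonyl carbon, and each stayed within the scatter. No step beyond the scatter is therefore expected in this assay. For compound 4 the estimated value is 7200 nM, with a range from 3600 nM to 14500 nM. The expected step is thus a 1.0-fold higher number from compound 1 to compound 4 (0.01 log units; within the scatter).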

Compound 4, half-maximal inhibitory concentration: 24500 nM
Compound 4: middle estimate off by 3.4-fold (0.53 log units), on the low side; measured number above the stated range.
By their numbers in this assay, from the lowest: compounds 3, 1 and 2 (each within the scatter of the next); then compound 4.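

In this assay the aryl group on the carbonyl carbon proves able to move the number, which the earlier exchanges at this place had not shown: 2-fluoro-4-methoxyphenyl gives a 3.4-fold higher number from compound 1 to compound 4 (0.54 log units; beyond the scatter), a 3.7-fold higher number from compound 3 to compound 4 (0.57 log units; beyond the scatter) and a 2.8-fold higher number from compound 2 to compound 4 (0.45 log units; beyond the scatter), all in the direction of weaker inhibition. The position is therefore not indifferent to what it carries, even though 4-methylphenyl, 4-bromophenyl and 3-fluorophenyl cannot be told apart there. The entering group brings a fluoro and a methoxy substituent together, along with one hydrogen-bond acceptor, and nothing available explains why this group stands apart from the other three.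

The compounds shown leave open whether the step belongs to the methoxy substituent, to the fluoro substituent or only to the two together, a question that 4-methoxyphenyl and 2-fluorophenyl on the same carbonyl carbon would address. Also open, going by these compounds, is how an aryl group bearing an amine or a carboxylic acid would behave at this place.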